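Enlarging the ring on the amino nitrogen of compound 2

The compounds below may be only part of what the source reports. "The series", "measured", "known", "first", "only" and "open" are said of these compounds alone.

Three compounds share one core and differ only in the group carried on a nitrogen on an aromatic ring. Compound 1 `CCCCC#Cc1nc(NC)c2ncn([C@H]3[C@H](O)[C@H](O)[C@@H]4C[C@@H]43)c2n1` bears a methyl there and gives 231 nM in an assay on RBL-2H3 cells for displacement of a labelled ligand from adenosine receptor A3 (Rattus norvegicus), with a stated time of 60 min; a higher number here means a weaker inhibitor, a lower number a stronger inhibitor. Compound 2 `CCCCC#Cc1nc(NC2CC2)c2ncn([C@H]3[C@H](O)[C@H](O)[C@@H]4C[C@@H]43)c2n1` bears a cyclopropyl and gives 39 nM in this assay, the lowest of the three numbers. Compound 3 `CCCCC#Cc1nc(N)c2ncn([C@H]3[C@H](O)[C@H](O)[C@@H]4C[C@@H]43)c2n1` bears a hydrogen and gives 65 nM in this assay.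

Two steps stand beyond the scatter: a 5.9-fold lower number from compound 1 to compound 2 (0.77 log units; beyond the scatter) and a 3.6-fold lower number from compound 1 to compound 3 (0.55 log units; beyond the scatter). The third, a 1.7-fold higher number from compound 2 to compound 3 (0.22 log units; within the scatter), lies within the scatter, so compound 2 and compound 3 cannot be ranked against each other.

Compound 4 `CCCCC#Cc1nc(NC2CCCC2)c2ncn([C@H]3[C@H](O)[C@H](O)[C@@H]4C[C@@H]43)c2n1` is not yet measured. Its difference from compound 2 is cyclopentyl in place of cyclopropyl on a nitrogen on an aromatic ring, that is, cyclopropylamino becomes cyclopentylamino. Going by the values given here, no measured step covers a ring of this size, so the expectation rests on the finding that the group on this nitrogen moves the number by modest amounts. For compound 4 a step of a 3.1-fold higher number from compound 2 to compound 4 (0.49 log units; beyond the scatter) is expected, a somewhat higher number than compound 2, with wide uncertainty. The estimate for compound 4 in this assay is 120 nM, within a range from 30 nM to 500 nM.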

Compound 4, inhibition constant: 58 nM
Beside the measured number, compound 4's estimate is 2.1-fold (0.32 log units) above it, within the range that was stated.
By their numbers in this assay, from the lowest: compounds 2, 4 and 3 (each within the scatter of the next); then compound 1.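

In this assay, the five-membered ring of cyclopentyl in place of the three-membered ring of cyclopropyl on this nitrogen gives a 1.5-fold higher number from compound 2 to compound 4 (0.17 log units; within the scatter) and so does not separate the two compounds. Cyclopentyl in place of hydrogen gives a 1.1-fold lower number from compound 3 to compound 4 (0.05 log units; within the scatter) and does not separate those two either, whereas cyclopentyl in place of methyl gives a 4.0-fold lower number from compound 1 to compound 4 (0.60 log units; beyond the scatter) and leaves compound 1 as the weakest of the four. The number therefore does not move steadily as the group grows from hydrogen through methyl and cyclopropyl to cyclopentyl: methyl alone stands apart, and hydrogen and both rings cannot be ranked against one another.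

Nothing given here explains why methyl stands apart. The compounds shown leave open whether ethyl or isopropyl, as open chains, would stand with methyl or with the rings, and whether a cyclohexyl or phenyl ring on this nitrogen would still give a number that cannot be told from those of compound 2 and compound 4.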